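Compound 3 and a Smaller Hydroxy-Methoxy Aryl Group

The source may report more compounds than this note shows. Statements on the series, on what has been measured and on what is new or still open speak of the compounds shown alone.

In a functional assay on A549 cells (Homo sapiens) for antiproliferative activity, read by sulforhodamine B assay, with a stated time of 48 h (a lower number here means a stronger inhibitor, a higher number a weaker inhibitor), compound 1 (`COc1ccc(/C=C/C(=O)C(=Cc2ccc(O)c(OC)c2)C(=O)/C=C/c2ccc(OC)cc2OC)c(OC)c1`) gives 590 nM, compound 2 (`COc1ccc(/C=C/C(=O)C(=Cc2cc(Br)c(O)c(OC)c2)C(=O)/C=C/c2ccc(OC)cc2OC)c(OC)c1`) gives 1090 nM and compound 3 (`COc1ccc(/C=C/C(=O)C(=Cc2cc(OC)c(O)c(OC)c2)C(=O)/C=C/c2ccc(OC)cc2OC)c(OC)c1`) gives 300 nM. Compound 3 therefore sits in the low group of this small set, and the data show a 3.6-fold lower number from compound 2 to compound 3 (0.56 log units; beyond the scatter). Compound 4 (`COc1ccc(/C=C/C(=O)C(=Cc2ccc(OC)c(O)c2)C(=O)/C=C/c2ccc(OC)cc2OC)c(OC)c1`) differs from it by 3-hydroxy-4-methoxyphenyl in place of 4-hydroxy-3,5-dimethoxyphenyl on a double-bonded chain carbon bound to a double-bonded chain carbon. Going by the values given here, no measured compound carries the 3-hydroxy-4-methoxyphenyl group, so no step tests it directly. The closest guide is the methoxy step, a 2.0-fold lower number from compound 1 to compound 3 (0.29 log units; within the scatter), and a step of similar small size is expected in this assay, towards a higher number if any. The expected change is a 1.7-fold higher number from compound 3 to compound 4 (0.22 log units; within the scatter). Compound 4 is estimated at 500 nM, with an expected range of 200 nM to 1300 nM.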

Compound 4, half-maximal inhibitory concentration: 380 nM
Estimate against measurement, compound 4: 1.3-fold (0.12 log units) above; the measured number falls inside the stated range.
By their numbers in this assay, from the lowest: compounds 3, 4, 1 and 2 (each within the scatter of the next, the first and the last beyond it).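

Replacing 4-hydroxy-3,5-dimethoxyphenyl with the smaller 3-hydroxy-4-methoxyphenyl on the double-bonded chain carbon leaves this assay within the scatter, with a 1.3-fold higher number from compound 3 to compound 4 (0.10 log units; within the scatter). Exchanging 4-hydroxy-3-methoxyphenyl for the same group gives a 1.6-fold lower number from compound 1 to compound 4 (0.19 log units; within the scatter), so this assay resolves no effect of that rearrangement. The clear difference involves only the bromo-bearing group, with a 2.9-fold lower number from compound 2 to compound 4 (0.46 log units; beyond the scatter).

Nothing available explains these steps. Going by these compounds, whether the hydroxy group is needed remains open, as does the effect of an amine or a carboxylic acid on this phenyl group.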